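A few compounds are considered here, and "the series" means these few. Any claim that something is new, unique, unknown or untested is made for them only; others in the source may bear on it.

The compounds measured in a functional assay on SMMC-7721 cells (Homo sapiens) for cytotoxicity, read by MTT assay, with a stated time of 24 h; on this read-out higher numbers stand for weaker inhibition and lower numbers for stronger inhibition:

Compound 1 `O=C1/C(=C/c2cccnc2)CN(S(=O)(=O)c2ccc([N+](=O)[O-])cc2)C/C1=C\c1ccccc1F` gives > 20000 nM, which is a limit of the assay rather than a number.
Compound 2 `O=C1/C(=C/c2cccnc2)CN(S(=O)(=O)c2ccc(C(F)(F)F)cc2)C/C1=C\c1ccccc1F` gives 7900 nM.
Compound 3 `O=C1/C(=C/c2ccncc2)CN(S(=O)(=O)c2ccc([N+](=O)[O-])cc2)C/C1=C\c1ccccc1C(F)(F)F` gives > 20000 nM, again a limit of the assay and not a number.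

Compounds 1 and 2 share one core and differ in a single place: trifluoromethyl in place of nitro on an aromatic carbon. In this assay this change produced an at least 2.5-fold lower number from compound 1 to compound 2 (0.40 log units; beyond the scatter). Because compound 1 sits at the limit of > 20000 nM in this assay, at which 2 of the 3 values shown sit, only the lower bound of that step is known; the true step may be larger.

Compound 3 carries a different core, and the difference between the core of compound 1 and the core of compound 3 is not broken down here. Compound 4 `O=C1/C(=C/c2ccncc2)CN(S(=O)(=O)c2ccc(C(F)(F)F)cc2)C/C1=C\c1ccccc1C(F)(F)F` has not yet been measured in this assay. It differs from compound 3 by the same change, at the same kind of place: trifluoromethyl in place of nitro on an aromatic carbon.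

Since compound 3 also stands at a limit, the starting point for the change is itself uncertain. Compound 4 is nevertheless expected to give a number rather than a limit, roughly 12000 nM, most likely between 5000 nM and 30000 nM. The expected step is an at least 1.6-fold lower number from compound 3 to compound 4 (0.22 log units; that floor lies within the scatter), resting on an at least 2.5-fold lower number from compound 1 to compound 2 (0.40 log units; beyond the scatter). That the change carries over from one core to the other is an assumption, not something these compounds show.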

Compound 4, half-maximal inhibitory concentration: 3840 nM
Estimate against measurement, compound 4: 3.1-fold (0.49 log units) above; the whole stated range lies above it.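

In this assay, the swap of nitro for trifluoromethyl on the aromatic ring again lowered the number, giving an at least 5.2-fold lower number from compound 3 to compound 4 (0.71 log units; beyond the scatter), so the direction seen on the core of compound 1 also held on the core of compound 3, and neither core goes against it. The two steps can only be set side by side as floors, and this comparison does not establish that the change has the same size on both cores: the same change on two cores in this assay, an at least 2.5-fold lower number (0.40 log units; beyond the scatter) from compound 1 to compound 2 and an at least 5.2-fold lower number (0.71 log units; beyond the scatter) from compound 3 to compound 4; the limit leaves it open whether they differ Each step starts from a nitro compound at the assay limit, so the result supports a shared direction across these two cores only, and says nothing about how large either step truly is or whether the change would carry over to any further core: the limit of > 20000 nM in this assay, at which 2 of the 4 values shown sit.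

The compounds shown leave open how other groups at this same place, such as an amine, a carboxylic acid or a nitrile, would read in this assay. They also leave open how the change would behave on cores carrying other groups in place of those that separate the core of compound 1 from the core of compound 3.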